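Swapping the Aryl Group on a Shared Core

The compounds below may be only part of what the source reports. "The series", "measured", "known", "first", "only" and "open" are said of these compounds alone.

Of the compounds shown here, three have been tested in a functional assay on HT-29 cells (Homo sapiens) for antiproliferative activity, read by MTT assay, with a stated time of 72 h; on this read-out lower numbers stand for stronger inhibition and higher numbers for weaker inhibition. Compound 1 `CNC(=O)c1cc(Oc2ccc(NC(=O)c3cc4cccnc4n(-c4ccc(C(F)(F)F)cc4Cl)c3=O)cc2)ccn1` gives 3190 nM in this assay. Compound 2 `CNC(=O)c1cc(Oc2ccc(NC(=O)c3cc4cccnc4n(-c4ccc(F)c(Cl)c4)c3=O)cc2)ccn1` gives 1810 nM in this assay. Compound 3 `CCCNC(=O)c1cc(Oc2ccc(NC(=O)c3cc4cccnc4n(-c4ccc(C(F)(F)F)cc4Cl)c3=O)cc2)ccn1` gives 1960 nM in this assay. Compound 4 `CCCNC(=O)c1cc(Oc2ccc(NC(=O)c3cc4cccnc4n(-c4ccc(F)c(Cl)c4)c3=O)cc2)ccn1` has not yet been measured, and the question is what it should give.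

Compound 2 differs from compound 1 in a single place: 3-chloro-4-fluorophenyl in place of 2-chloro-4-(trifluoromethyl)phenyl on an aromatic nitrogen. That change gave a 1.8-fold lower number from compound 1 to compound 2 (0.25 log units; within the scatter), a shift too small to count as a real gain. Compound 4 differs from compound 3 by the same change: 3-chloro-4-fluorophenyl in place of 2-chloro-4-(trifluoromethyl)phenyl on an aromatic nitrogen. The place of the change reads identically in both pairs, so it is the same change made on a slightly different core. The two cores differ in one spot only: compound 3 differs from compound 1 by ethyl in place of hydrogen on a saturated chain carbon bound to an amide-type nitrogen, and that change gave a 1.6-fold lower number from compound 1 to compound 3 (0.21 log units; within the scatter), again within the ordinary spread of repeat measurements.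

Because the same aryl swap already gave a 1.8-fold lower number from compound 1 to compound 2 (0.25 log units; within the scatter), the expectation is a 1.8-fold lower number from compound 3 to compound 4 (0.25 log units; within the scatter). This rests on one earlier example only, so the uncertainty is wide. Compound 4 is therefore estimated at 1100 nM, most likely between 500 nM and 2500 nM.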

Compound 4, half-maximal inhibitory concentration: 920 nM
Beside the measured number, compound 4's estimate is 1.2-fold (0.08 log units) above it; the range from low to high includes it.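

In this assay, the aryl swap gave a 2.1-fold lower number from compound 3 to compound 4 (0.33 log units; beyond the scatter), which sits close to what the same swap did on the core of compound 1: the same change on two cores in this assay, a 1.8-fold lower number (0.25 log units; within the scatter) from compound 1 to compound 2 and a 2.1-fold lower number (0.33 log units; beyond the scatter) from compound 3 to compound 4, 1.2-fold (0.08 log units) apart, within the scatter of two such steps. The ethyl-for-hydrogen change on the chain attached to the amide nitrogen gave a 2.0-fold lower number from compound 2 to compound 4 (0.29 log units; within the scatter), and it also matches its earlier example: the same change on two cores in this assay, a 1.6-fold lower number (0.21 log units; within the scatter) from compound 1 to compound 3 and a 2.0-fold lower number (0.29 log units; within the scatter) from compound 2 to compound 4, 1.2-fold (0.08 log units) apart, within the scatter of two such steps. Going by these compounds alone, each change therefore carried over between these two cores with no detectable difference in size, but this rests on one pair of steps per change, only the step to compound 4 from compound 3 lies beyond the scatter, and it says nothing about other cores or about why either change acts as it does.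

The aryl swap replaces the whole group at once, so the compounds shown leave open whether the chlorine's place or the exchange of trifluoromethyl for fluorine accounts for the step, which a plain phenyl or a 4-fluorophenyl on the aromatic nitrogen could help separate. They also leave open whether the trend on the amide chain would continue with a longer chain such as butyl, or change with a cyclopropyl group or a chain ending in an amine.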